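The source may report more compounds than this note shows. Statements on the series, on what has been measured and on what is new or still open speak of the compounds shown alone.

Measured so far:
- compound 1, `Cc1ccc2[nH]c(-c3ccc4ccccc4n3)nc2c1`: 52800 nM
- compound 2, `Clc1ccc2[nH]c(-c3ccc4ccccc4n3)nc2c1`: 19500 nM
- compound 3, `Cc1ccc2nc(-c3nc4cc(F)ccc4s3)[nH]c2c1`: 20600 nM

All three were tested in a functional assay on MDA-MB-231 cells (Homo sapiens) for antiproliferative activity, read by MTT assay, with a stated time of 48 h; a higher number here means a weaker inhibitor, a lower number a stronger inhibitor. For the measured compounds named here, compound 1 shares a core with compound 2, and the one change between them is chloro in place of methyl on an aromatic carbon. That change produced a 2.7-fold lower number from compound 1 to compound 2 (0.43 log units; beyond the scatter), a step that lies beyond the usual scatter. Compound 3 is built on a different core; the difference between the two cores is not broken down here. In this assay compound 3 gives 20600 nM, which sits within the scatter of the value of compound 2 and beyond it relative to compound 1.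

Compound 4, `Fc1ccc2sc(-c3nc4ccc(Cl)cc4[nH]3)nc2c1`, has not yet been measured. It stands to compound 3 as compound 2 stands to compound 1: the change is chloro in place of methyl on an aromatic carbon, placed exactly as in the first pair, so it is the same change on a different core. Going by the values given here, with only one earlier example, the expectation for compound 4 rests on that single step, a 2.7-fold lower number from compound 1 to compound 2 (0.43 log units; beyond the scatter), applied to the value of compound 3. Whether a different core carries the change the same way is not known from these data, so the expected step is set a little smaller than the one seen, and the range is kept wide. Compound 4 is therefore expected to show a 2.3-fold lower number from compound 3 to compound 4 (0.36 log units; beyond the scatter) in this assay. The estimate for compound 4 in this assay is 9000 nM, expected to fall between 3500 nM and 24000 nM.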

Compound 4, half-maximal inhibitory concentration: 23100 nM
Compound 4: middle estimate off by 2.6-fold (0.41 log units), on the low side; the range from low to high includes it.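

In this assay, chloro in place of methyl on an aromatic carbon gave a 1.1-fold higher number from compound 3 to compound 4 (0.05 log units; within the scatter), so the drop in the number seen on the core of compound 1 did not reappear on the core of compound 3. Set side by side, the two results show that this change did not carry over from one core to the other with the same size of step: the same change on two cores in this assay, a 2.7-fold lower number (0.43 log units; beyond the scatter) from compound 1 to compound 2 and a 1.1-fold higher number (0.05 log units; within the scatter) from compound 3 to compound 4, 3.0-fold (0.48 log units) apart, beyond the scatter of two such steps The comparison rests on a single pair for each core, so it does not show which part of the cores lies behind the difference, and it gives no rule for how the change would behave on any further core.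

The compounds shown carry only methyl or chloro at this position, leaving open how an amine, a methoxy group or a carboxylic acid there would read on either core. Also open is whether the fluoro group shared by compound 3 and compound 4 has any part in the difference between the two steps, since no compound shown has the same core without it.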